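This account rests on a few compounds, and the source may have more. Where it says the series, first, only, none or still open, it means among the compounds named here.

Compound 1 `C=C1[C@H](C)CCC[C@]1(C)CC/C(C)=C/CC1=C(O)C(=O)C=C(OC)C1=O` carries a hydroxy group on its shared core. In a functional assay on COLO 205 cells (Homo sapiens) for cytotoxicity, read by MTT assay (on this read-out higher numbers stand for weaker inhibition and lower numbers for stronger inhibition), compound 1 gives 0.1 ug/mL, the lowest of the two numbers recorded here. Compound 2 `C=C1[C@H](C)CCC[C@]1(C)CC[C@@]1(C)C=Cc2c(OC(C)=O)c(OC(C)=O)cc(OC)c2O1` gives 0.22 ug/mL in this assay, a higher number than compound 1 by a margin beyond the usual scatter. Compound 3 `C=C1[C@H](C)CCC[C@]1(C)CC[C@@]1(C)C=Cc2c(OC(C)=O)c(OC)cc(OC(C)=O)c2O1` reaches only the limit of > 10 ug/mL in this assay, so it offers no number to compare. That reading is the limit of > 10 ug/mL in this assay, at which 1 of the 3 values shown sits. Compound 4 `C=C1[C@H](C)CCC[C@]1(C)CC/C(C)=C/CC1=C(OC)C(=O)C=C(OC)C1=O` has not yet been measured. It differs from compound 1 in one place: methyl in place of hydrogen on an oxygen on an unsaturated carbon. Within the data shown here, no measured pair shows this same change, so what it does must be judged from the change alone, without a precedent among the compounds here. The expectation is that the step from compound 1 to compound 4 is a 3.0-fold higher number from compound 1 to compound 4 (0.48 log units; beyond the scatter), a modest weakening that may still fall within the scatter of repeated runs. On that basis compound 4 is estimated at 0.3 ug/mL in this assay, with a plausible range from 0.08 ug/mL to 1.5 ug/mL.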

Compound 4, half-maximal inhibitory concentration: > 10 ug/mL
Compound 4: no number, only a limit; the forecaster's own chance of this, stated with the estimate: 5%; middle value at least 33-fold (1.52 log units) away from the limit.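

Turning the hydroxy group of compound 1 into a methoxy group is the first change in this set that can be read on its own, and in this assay it gives an at least 100-fold higher number from compound 1 to compound 4 (2.00 log units; beyond the scatter). A single added carbon on this oxygen is therefore enough to take the compound from the most sensitive end of the measured values to the end of the assay's range. Compound 4 reads only as a limit of the assay, not as a number, so the step is a minimum and not an exact size, and it is not alone there: the limit of > 10 ug/mL in this assay, at which 2 of the 4 values shown sit.

From the compounds shown here alone, it remains open whether the loss of the hydrogen or the arrival of the methyl matters more, and an amino group or an ethoxy group at this place could help separate the two. Among these compounds, no second pair shows whether hydroxy to methoxy has a similar effect elsewhere on the core.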